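Ketone to Amide at the Carbonyl Carbon

A few compounds are considered here, and "the series" means these few. Any claim that something is new, unique, unknown or untested is made for them only; others in the source may bear on it.

Measured compounds:
- compound 1, `COc1ccc2c(c1)OC(c1cc(OC)c(OC)c(OC)c1)C(C(=O)N(C)OC)=C2`: 11700 nM
- compound 2, `CCCC(=O)C1=Cc2ccc(OC)cc2OC1c1cc(OC)c(OC)c(OC)c1`: 11700 nM

Both measured compounds share a core and differ only in the group on the carbonyl carbon. In a functional assay for inhibition of nuclear factor NF-kappa-B complex (Homo sapiens) (a lower number here means a stronger inhibitor, a higher number a weaker inhibitor), compound 1 gives 11700 nM, and compound 2 gives 11700 nM. The step of no change at the digits printed from compound 1 to compound 2 (within the scatter) shows that replacing the methoxy(methyl)amino group with a propyl chain left the activity where it was. Compound 2 therefore stands level with compound 1, and neither can be called the stronger inhibitor.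

Compound 3, `CCNC(=O)C1=Cc2ccc(OC)cc2OC1c1cc(OC)c(OC)c(OC)c1`, is the next variation at the same place. Its difference from compound 2 is ethylamino in place of propyl on a carbonyl carbon. Going by the values given here, the only measured step that touches this position is no change at the digits printed from compound 1 to compound 2 (within the scatter), and it was flat. Going from a propyl chain to an ethylamino group brings in a hydrogen-bond donor that neither measured compound carries, so the single flat step is only a loose guide. Still, with no change seen so far at this position, a step of no change at the digits printed from compound 2 to compound 3 (within the scatter) is expected, that is, none beyond the scatter. Compound 3 is estimated at 11700 nM, with a range from 4000 nM to 35000 nM.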

Compound 3, half-maximal inhibitory concentration: > 50000 nM
Compound 3 was reported as a limit; the forecaster's own chance of this, stated with the estimate: 10%; at least 4.2-fold (0.63 log units) between middle value and limit.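

In this assay compound 3 gives > 50000 nM, and this value is a limit of the assay, not a number. Even so, the group on this carbonyl carbon clearly matters, which the level pair of earlier compounds could not show: ethylamino in place of propyl gives an at least 4.2-fold higher number from compound 2 to compound 3 (0.63 log units; beyond the scatter), and ethylamino in place of methoxy(methyl)amino gives an at least 4.2-fold higher number from compound 1 to compound 3 (0.63 log units; beyond the scatter). Of the three groups shown, ethylamino is the only one with a hydrogen-bond donor and also the one that gives the weakest inhibitor, but three compounds make no rule, and the full size of the loss cannot be read from the result: the limit of > 50000 nM in this assay, at which 1 of the 3 values shown sits.

The compounds shown do not tell whether the loss follows the amide hydrogen or the ethylamino group as a whole, and a dimethylamino group on the same carbonyl carbon would help to separate the two. They also leave open whether any other group here, such as a longer chain like butyl or a small ring like cyclopropyl, could give a stronger inhibitor than compound 1 and compound 2.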